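Amine substituent change: compound 3 to compound 4

The source may report more compounds than this note shows. Statements on the series, on what has been measured and on what is new or still open speak of the compounds shown alone.

Measured compounds:
compound 1 `O=C(C1=C(OC2CCCCC2)C(=O)N(CCCn2ccnc2)C1c1ccc(Br)cc1)c1ccccc1`, 22400 nM
compound 2 `NC1=C(C(=O)c2ccccc2)C(c2ccc(Br)cc2)N(CCCn2ccnc2)C1=O`, 149000 nM
compound 3 `O=C(C1=C(Nc2ccc(I)cc2)C(=O)N(CCCn2ccnc2)C1c1ccc(Br)cc1)c1ccccc1`, 12000 nM

In a functional assay on U2OS cells (Homo sapiens) for antiproliferative activity, read by MTT assay, with a stated time of 72 h (a higher number here means a weaker inhibitor, a lower number a stronger inhibitor), compound 3 holds the lowest number of the three. Its nearest neighbour is compound 1, and the step of a 1.9-fold lower number from compound 1 to compound 3 (0.27 log units; within the scatter) stays within the scatter. The furthest is compound 2, and the step of a 12-fold lower number from compound 2 to compound 3 (1.09 log units; beyond the scatter) is large; the step of a 6.7-fold higher number from compound 1 to compound 2 (0.82 log units; beyond the scatter) also lies beyond the scatter. What the series shows so far is that an unsubstituted amino group on the double-bonded ring carbon sits well above both the cyclohexyloxy and the (4-iodophenyl)amino groups, while those two are not separated beyond the scatter.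

Compound 4 `O=C(C1=C(Nc2ccccc2Br)C(=O)N(CCCn2ccnc2)C1c1ccc(Br)cc1)c1ccccc1` differs from compound 3 in one place: 2-bromophenyl in place of 4-iodophenyl on an amine nitrogen. Going by the values given here, no measured pair compares two different aryl groups on this amine nitrogen, so none of the steps bears directly on the change. Among the compounds with values here, the only step touching this nitrogen, from compound 2 to compound 3, concerns the presence of an aryl group rather than its identity, and compound 4 keeps an aryl group there. The expectation is therefore a step of no clear direction in this assay, likely within the scatter, and compound 4 is expected at 15000 nM with a range of 5000 nM to 45000 nM. The expected step of a 1.3-fold higher number from compound 3 to compound 4 (0.10 log units; within the scatter) rests on this reasoning and carries wide uncertainty.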

Compound 4, half-maximal inhibitory concentration: 16900 nM
Estimate against measurement, compound 4: 1.1-fold (0.05 log units) below, within the range that was stated.
By their numbers in this assay, from the lowest: compounds 3, 4 and 1 (each within the scatter of the next); then compound 2.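

In this assay, going by these compounds alone, the step of a 1.4-fold higher number from compound 3 to compound 4 (0.15 log units; within the scatter) gives the first direct comparison of two aryl groups on this amine nitrogen, and it does not separate 2-bromophenyl from 4-iodophenyl, although the pair cannot show what the halogen and its place on the ring each contribute. The gain over the unsubstituted amino group also holds with a second aryl group, as an 8.8-fold lower number from compound 2 to compound 4 (0.95 log units; beyond the scatter) lies beyond the scatter, while a 1.3-fold lower number from compound 1 to compound 4 (0.12 log units; within the scatter) leaves (2-bromophenyl)amino unseparated from cyclohexyloxy, as (4-iodophenyl)amino was. Nothing available on these compounds gives a reason for these steps.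

Still open, as far as these compounds go, is whether the identity of the aryl group matters at all on this nitrogen: a 4-bromophenyl group would set the halogen's place apart from its identity, and a plain phenyl group would test the need for a halogen. A non-aromatic substituent such as cyclohexyl or benzyl on the same nitrogen would show whether the gain over the unsubstituted amino group requires an aryl ring directly attached.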